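The compounds below may be only part of what the source reports. "The series", "measured", "known", "first", "only" and "open" are said of these compounds alone.

Of the compounds shown here, three have so far been measured in an in vitro functional assay on HEK ts201 cells for antagonist activity at Neuronal acetylcholine receptor; alpha4/beta2 (Homo sapiens), read by fluorescence and calcium flux; on this read-out higher numbers stand for weaker inhibition and lower numbers for stronger inhibition. Compound 1 `CC1CC(=O)N(c2ccccc2C(=O)OCC2CCCN(CCCCCc3ccccc3)C2)C1=O` gives 24500 nM in this assay, the highest of the three numbers, so among them it is the weakest inhibitor. Compound 2 `O=C(OCC1CCCN(CCCc2ccccc2)C1)c1ccccc1-c1cccc2ccccc12` gives 11700 nM, a number that lies below that of compound 1 by more than the usual scatter, and compound 3 `CN1CCCC(COC(=O)c2ccccc2-c2ccccc2)C1` gives 6920 nM, also below compound 1 by more than the scatter. Among the compounds with values here, no pair of these three compounds differs in a single place, so none of the comparisons can be read as a clean step from one structure to the next.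

Compound 4 `CC1CC(=O)N(c2ccccc2C(=O)OCC2CCCN(CCCCOc3ccc(Cl)c(Cl)c3)C2)C1=O` is built from compound 1 by one change: 3,4-dichlorophenoxy in place of benzyl on a saturated chain carbon, four bonds along the chain from an amine nitrogen in a ring. Within the data shown here, no measured pair shows this change, so nothing in the numbers gathered so far fixes its size or its direction. With the rest of the structure kept, compound 4 is expected to stay in the same weak region as compound 1, and the step of a 1.6-fold lower number from compound 1 to compound 4 (0.21 log units; within the scatter) is expected to be small, a modest move toward stronger inhibition that may well not exceed the scatter. Compound 4 is therefore estimated at 15000 nM in this assay, with a range from 5000 nM to 45000 nM.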

Compound 4, half-maximal inhibitory concentration: 12300 nM
The estimate for compound 4 lay 1.2-fold (0.09 log units) above the measured number; the measured number falls inside the stated range.
By their numbers in this assay, from the lowest: compounds 3, 2, 4 and 1 (each within the scatter of the next, the first and the last beyond it).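

Within the data shown here, this pair gives the first clean single-place comparison: in this assay, putting 3,4-dichlorophenoxy in place of benzyl on a saturated chain carbon, four bonds along the chain from an amine nitrogen in a ring, gives a 2.0-fold lower number from compound 1 to compound 4 (0.30 log units; within the scatter). The entering group brings oxygen, chlorine and a hydrogen-bond acceptor that benzyl lacks, yet this exchange does not separate the two compounds on this read-out, so at this position the terminal group can be changed this far with no difference beyond the scatter. Nothing measured explains this result, and no independent data bear on it.

Among these compounds, the single step cannot divide the contribution of the ether oxygen from that of the two chlorines, a question that an unsubstituted phenoxy group or a 3,4-dichlorobenzyl group at the same place would address. It also leaves open whether a more different end group, such as an amine or a carboxylic acid, would move the number beyond the scatter, and whether the same exchange would behave alike on the cores of compound 2 or compound 3.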